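Benzyl-to-hydrogen steps in a cytotoxicity series

A few compounds are considered here, and "the series" means these few. Any claim that something is new, unique, unknown or untested is made for them only; others in the source may bear on it.

Measured so far:
compound 1, `COc1cc(OC)c2cc(-c3ccc(OCc4ccccc4)cc3)c(O)nc2c1`, 10000 nM
compound 2, `COc1ccc(-c2cc3c(OC)cc(OC)cc3n(CC(=O)OCc3ccccc3)c2=O)cc1`, 10000 nM
compound 3, `COc1ccc(-c2cc3c(OC)cc(OC)cc3n(CC(=O)O)c2=O)cc1`, 10000 nM

All three were run in a functional assay on HCT-15 cells (Homo sapiens) for cytotoxicity, read by colorimetric assay and MTT assay; a higher number here means a weaker inhibitor, a lower number a stronger inhibitor. Compound 1 gives 10000 nM, compound 2 gives 10000 nM and compound 3 gives 10000 nM; the three stand level at the digits shown, and nothing separates them within the scatter. Compound 2 and compound 3 share a core and differ in one place: hydrogen in place of benzyl on an oxygen next to a carbonyl group. The step is no change at the digits printed from compound 2 to compound 3 (within the scatter). The difference between the core of compound 1 and the core of compound 2 is not broken down here.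

Compound 4, `COc1cc(OC)c2cc(-c3ccc(O)cc3)c(O)nc2c1`, has not yet been measured in this assay. It stands to compound 1 as compound 3 stands to compound 2: hydrogen in place of benzyl on an oxygen on an aromatic ring. This is the same kind of change, not the same change: between compound 2 and compound 3 the place is on an oxygen next to a carbonyl group whose other neighbours are carbonyl carbon, whereas between compound 1 and compound 4 the place is on an oxygen on an aromatic ring whose other neighbours are aromatic carbon. This kind of change occurs twice among the compounds shown, once measured.

Among the measured compounds shown here, the expectation rests on compound 1 at 10000 nM and on the one measured instance, no change at the digits printed from compound 2 to compound 3 (within the scatter), which left the read-out unmoved. A step of about no change at the digits printed from compound 1 to compound 4 (within the scatter) is expected on that basis. Compound 4 is therefore expected near 10000 nM, with a range from 4000 nM to 25000 nM.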

Compound 4, half-maximal inhibitory concentration: 10000 nM
Beside the measured number, compound 4's estimate shows no gap at the digits printed, and the stated range covers the measured number.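

In this assay, hydrogen in place of benzyl on an oxygen on an aromatic ring gives no change at the digits printed from compound 1 to compound 4 (within the scatter). Set beside the earlier replacement on an oxygen next to a carbonyl group, the change reads alike on both cores: the same change on two cores in this assay, no change at the digits printed (within the scatter) from compound 2 to compound 3 and no change at the digits printed (within the scatter) from compound 1 to compound 4, 1.0-fold (0.00 log units) apart, within the scatter of two such steps

This agreement is between two flat steps, and compound 4 at 10000 nM still stands level with the other three compounds. Neither step starts from a compound that reads apart from the rest of the series, so the pairs do not show whether the same change would stay silent on a compound with a different read-out, and two pairs at two different kinds of place are a narrow basis for any general rule.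

The compounds shown leave open whether a group other than benzyl or hydrogen on the oxygen of compound 4, such as an amine carried on a longer chain, would read apart from compound 4 in this assay. Also open is how the core of compound 1 and the core of compound 2 compare when they carry the same groups, since no pair shown isolates that difference.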